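This account rests on a few compounds, and the source may have more. Where it says the series, first, only, none or still open, it means among the compounds named here.

Compound 1 `COc1ccc(/C=C/C2(C)C=CC(=O)O2)cc1OC`: > 1000000 nM (a limit)
Compound 2 `COc1ccc(/C=C/C2(C)C=CC(=O)O2)c(OC)c1OC`: > 1000000 nM (a limit)
Compound 3 `COc1cc(OC)c(OC)cc1/C=C/C1(C)C=CC(=O)O1`: > 1000000 nM (a limit)

In a functional assay on K562 cells (Homo sapiens) for inhibition, read by sulforhodamine B assay, with a stated time of 48 h (a higher number here means a weaker inhibitor of growth, a lower number a stronger inhibitor of growth), compound 1 has no number, only a limit, and stands at the limit of > 1000000 nM in this assay, at which 3 of the 3 values shown sit. Compound 4 `COc1cc(/C=C/C2(C)C=CC(=O)O2)cc(OC)c1OC` differs from compound 1 by one change: methoxy in place of hydrogen on an aromatic carbon. Two measured steps are the same kind of change, methoxy in place of hydrogen on an aromatic carbon: a step that the two limits leave unreadable from compound 1 to compound 2 and a step that the two limits leave unreadable from compound 1 to compound 3. Neither gives a size or a direction, and neither compound 2 nor compound 3 came off the limit. No step beyond the scatter is therefore expected in this assay, and another limit is the likeliest report. The expected step is a number no higher from compound 1 to compound 4 (the limit leaves the size open). For compound 4 the estimate is 1000000 nM, with an expected range of 300000 nM to 2000000 nM.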

Compound 4, concentration for total growth inhibition: > 1000000 nM
Compound 4: no number, only a limit; the forecaster's own chance of this, stated with the estimate: 75%; the middle value lies on the limit itself.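

Compound 4 gives > 1000000 nM in this assay, a limit and not a number, so its step from compound 1 cannot be read. The compounds shown leave open whether methoxy in place of hydrogen on an aromatic carbon changes growth inhibition at all.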